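This account rests on a few compounds, and the source may have more. Where it says the series, first, only, none or still open, it means among the compounds named here.

Of the compounds shown here, two have numbers so far in a functional assay on HCT-116 cells (Homo sapiens) for antiproliferative activity, read by MTT assay, with a stated time of 72 h (a lower number here means a stronger inhibitor, a higher number a weaker inhibitor), and they sit some way apart. Compound 1 (`COc1cccc(N2C(=O)COc3ccc(-c4cnc5ccccc5c4)cc32)c1`) gives 8240 nM in this test, while compound 2 (`O=C1COc2ccc(-c3cccc(NS(=O)(=O)c4ccc(F)cc4)c3)cc2N1c1ccc(Cl)cc1`) gives 23900 nM as the higher of the two numbers. That gap lies beyond the usual scatter of repeated measurements, but the pair differs in more than one place, so it cannot be pinned on any single group.

Compound 3 (`Cc1ccc(N2C(=O)COc3ccc(-c4cccc(NS(=O)(=O)c5ccc(F)cc5)c4)cc32)cc1`) stays much closer to compound 2 and changes it in one place (methyl in place of chloro on an aromatic carbon), with methyl in place of chloro on an aromatic carbon, so that 4-chlorophenyl becomes 4-methylphenyl. Within the data shown here, no measured pair shows what this swap does in this assay here, so the direction stays open and no step beyond the scatter is expected. The estimate therefore starts from compound 2 at 23900 nM as its closest measured relative. The expected change is small, with a 1.2-fold lower number from compound 2 to compound 3 (0.08 log units; within the scatter) as the estimated step. For compound 3 the estimated value is 20000 nM with 9000 nM as the expected lower end and 45000 nM as the expected upper end of the range.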

Compound 3, half-maximal inhibitory concentration: 35600 nM
Estimate against measurement, compound 3: 1.8-fold (0.25 log units) below; the measured number falls inside the stated range.
By their numbers in this assay, from the lowest: compound 1; then compounds 2 and 3 (each within the scatter of the next).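

In this assay, among these compounds, the change from 4-chlorophenyl to 4-methylphenyl gives a 1.5-fold higher number from compound 2 to compound 3 (0.17 log units; within the scatter), the first direct reading of a single swap. At this position, on a six-membered aromatic ring of carbon only and para to a large group, chloro and methyl therefore cannot be told apart in this test, although this rests on one pair of compounds and one background. No measurement shown here explains this result, so the reason for the similar readings remains unknown.

The compounds shown leave open whether this insensitivity extends to quite different groups at the same position, such as a carboxylic acid, an amine or a nitrile, any of which would test the position more sharply than a swap between two single-atom substituents. Among the compounds shown here, they also leave open whether the same swap would give a similar result with the quinoline-free sulfonamide side of the molecule replaced, as the only compound with a different side, compound 1, differs from the others in more than one place.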